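The source may hold more compounds than are shown below. What is called first, only, known or untested is meant among the compounds shown, and "the series" means these compounds.

Measured compounds in a functional assay on A549 cells (Homo sapiens) for antiproliferative activity, read by MTT assay; a higher number here means a weaker inhibitor, a lower number a stronger inhibitor:
compound 1 `CC(C)COC(=O)N1CCCc2cc(S(=O)(=O)N3CC(c4ccccc4)NC3=O)ccc21` — > 20000 nM
compound 2 `C=CCOC(=O)N1CCCc2cc(S(=O)(=O)N3CC(c4ccccc4)NC3=O)ccc21` — 4310 nM
compound 3 `O=C(CCl)NC(=O)N1CCCc2cc(S(=O)(=O)N3CC(c4ccccc4)NC3=O)ccc21` — 449 nM

The value for compound 1 is a limit of the assay, not a number (the limit of > 20000 nM in this assay, at which 1 of the 3 values shown sits). Compound 4 `O=C(NC1CCCCC1)N1CCCc2cc(S(=O)(=O)N3CC(c4ccccc4)NC3=O)ccc21` differs from compound 1 by cyclohexylamino in place of isobutoxy on a carbonyl carbon. Among the measured compounds shown here, two measured steps bear on exchanges at this carbonyl carbon: an at least 4.6-fold lower number from compound 1 to compound 2 (0.66 log units; beyond the scatter) and an at least 44-fold lower number from compound 1 to compound 3 (1.64 log units; beyond the scatter), the latter being the closer parallel, since it too puts a nitrogen-linked group in place of isobutoxy. For the measured compounds named here, every change made at this position so far has lowered the number beyond the scatter. For compound 4 a lowering beyond the scatter is therefore expected, an at least 6.6-fold lower number from compound 1 to compound 4 (0.82 log units; beyond the scatter). Compound 4 is estimated at 3000 nM, within 700 nM to 15000 nM.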

Compound 4, half-maximal inhibitory concentration: 231 nM
Compound 4: the middle estimate sits 13-fold (1.11 log units) above what was measured; measured number below the stated range.
By their numbers in this assay, from the lowest: compounds 4 and 3 (each within the scatter of the next); then compound 2. At a limit, above all of these: compound 1.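

A nitrogen-linked group at this carbonyl carbon needs no chloromethyl carbonyl to reach the low range in this assay, since replacing it with cyclohexyl gives a 1.9-fold lower number from compound 3 to compound 4 (0.29 log units; within the scatter). Relative to the oxygen-linked groups, cyclohexylamino gives a 19-fold lower number from compound 2 to compound 4 (1.27 log units; beyond the scatter) and an at least 86-fold lower number from compound 1 to compound 4 (1.93 log units; beyond the scatter). Compound 1 stands at a limit of the assay, not a number: the limit of > 20000 nM in this assay, at which 1 of the 4 values shown sits.

Cyclohexyloxy would show whether the linking nitrogen or the cyclohexyl ring carries the gain. Dimethylamino and phenylamino would test the amide hydrogen and the saturated ring.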